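From a Hydroxyethyl Amide to a Diethyl Amide

A few compounds are considered here, and "the series" means these few. Any claim that something is new, unique, unknown or untested is made for them only; others in the source may bear on it.

Compound 1 `O=C(NCCO)c1cc(-c2ccc(Cl)cc2Cl)n[nH]1` was tested in an assay on isolated protein for inhibition of alkaline phosphatase, tissue-nonspecific isozyme (Homo sapiens) (on this read-out lower numbers stand for stronger inhibition and higher numbers for weaker inhibition), where compound 1 gives 44 nM. Among the compounds with values here, its only measured neighbour, compound 2 `COCCNC(=O)c1cc(-c2ccc(Cl)cc2Cl)n[nH]1`, gives 46 nM in this assay. Within the data shown here, of the two recorded numbers that of compound 1 stands lowest, yet the step of a 1.0-fold higher number from compound 1 to compound 2 (0.02 log units; within the scatter) lies within the scatter, so the two compounds cannot be told apart; that step, methyl in place of hydrogen on an oxygen on a saturated carbon, is the only measured change available.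

Compound 3 `CCN(CC)C(=O)c1cc(-c2ccc(Cl)cc2Cl)n[nH]1` differs from compound 1 as follows: diethylamino in place of (2-hydroxyethyl)amino on a carbonyl carbon. The (2-hydroxyethyl)amino group leaves and diethylamino enters on the carbonyl carbon. Among the measured compounds shown here, the one measured step touches only the oxygen of that group and changed nothing beyond the scatter; nothing measured speaks to the loss of the other hydrogen-bond donor. Because a 1.0-fold higher number from compound 1 to compound 2 (0.02 log units; within the scatter) was flat, only a modest weakening is expected, with wide uncertainty. Compound 3 is therefore estimated to give about 90 nM, within a range from 30 nM to 300 nM, an expected step of a 2.0-fold higher number from compound 1 to compound 3 (0.31 log units; beyond the scatter).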

Compound 3, half-maximal inhibitory concentration: 285 nM
Estimate against measurement, compound 3: 3.2-fold (0.50 log units) below, within the range that was stated.
By their numbers in this assay, from the lowest: compounds 1 and 2 (each within the scatter of the next); then compound 3.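

Diethylamino in place of (2-hydroxyethyl)amino on a carbonyl carbon gives a 6.5-fold higher number from compound 1 to compound 3 (0.81 log units; beyond the scatter) in this assay, which shows that this position does respond to change, although the earlier step on the oxygen alone left the number flat. Diethylamino in place of (2-methoxyethyl)amino gives a 6.2-fold higher number from compound 2 to compound 3 (0.79 log units; beyond the scatter), so the weakening also appears when the group that leaves has no hydroxyl hydrogen, and that hydrogen alone cannot be what separates compound 3 from the other two. No measured evidence bears on why the number rises at this position.

The change on the carbonyl carbon removes the amide hydrogen and the oxygen of the chain together and also alters the chain, so the compounds shown cannot assign the weakening to any one of these. Ethylamino would keep the amide hydrogen without the chain oxygen, (2-hydroxyethyl)(methyl)amino would keep the chain oxygen without the amide hydrogen, and how either would stand against compound 1 and compound 3 remains open.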